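Moving the carboxylate and dropping the chlorine on compound 1

The source may hold more compounds than are shown below. What is called first, only, known or untested is meant among the compounds shown, and "the series" means these compounds.

In an assay on HEK293 cells for positive allosteric modulation of metabotropic glutamate receptor 2 (Rattus norvegicus), read by thallium flux, with a stated time of 2.5 min (on this read-out lower numbers stand for an effect already at smaller amounts and higher numbers for an effect only at larger amounts of compound), compound 1 `Cc1c(OCCCCOc2ccc(C(=O)O)cc2Cl)ccc(C(=O)CC2CCCC2)c1O` gives 237 nM. Among the three measured compounds this places compound 1 second highest: compound 3 `Cc1c(OCCCCOc2ccc(C(=O)O)cc2Cl)ccc(C(=O)CC(C)C)c1O` gives 96 nM, a step described as a 2.5-fold lower number from compound 1 to compound 3 (0.39 log units; beyond the scatter), while compound 2 `Cc1c(OCCCCOc2ccc(C(=O)O)c(Cl)c2)ccc(C(=O)CC2CCCC2)c1C` gives 2420 nM. Compound 4 `Cc1c(OCCCCOc2cccc(C(=O)O)c2)ccc(C(=O)CC2CCCC2)c1O` has not yet been measured in this assay. Relative to compound 1 the change is 3-carboxyphenyl in place of 4-carboxy-2-chlorophenyl on an oxygen on a saturated carbon. For the measured compounds named here, no measured step bears directly on this change: the only step on hand, from compound 1 to compound 3, concerns the group on a saturated chain carbon bound to a carbonyl carbon, not the aryl ether end, and compound 2 differs from compound 1 in two places at once, so its value can only be set beside that of compound 1. With the chlorine removed and the carboxyl group relocated, a weaker effect is expected for compound 4, estimated as a 3.4-fold higher number from compound 1 to compound 4 (0.53 log units; beyond the scatter). Compound 4 is therefore estimated at 800 nM, with a range from 250 nM to 3000 nM.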

Compound 4, half-maximal effective concentration: 451 nM
For compound 4 the middle estimate is 1.8-fold (0.25 log units) above the measured one, and the stated range covers the measured number.
By their numbers in this assay, from the lowest: compound 3; then compounds 1 and 4 (each within the scatter of the next); then compound 2.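

In this assay, for the compounds shown here, 3-carboxyphenyl in place of 4-carboxy-2-chlorophenyl on an oxygen on a saturated carbon gives a 1.9-fold higher number from compound 1 to compound 4 (0.28 log units; within the scatter), the first single-place reading at this end of the molecule. The earlier step concerned only the other end, whereas this one shows that this end tolerates the loss of the chlorine and a new place for the carboxyl group, taken together, with compound 1 and compound 4 not distinguishable on this read-out. Nothing measured here accounts for this outcome.

The two alterations are made at once, so the compounds shown do not separate what the chlorine and the place of the carboxyl group each contribute, and opposing effects that cancel cannot be excluded. They also leave open whether a tetrazole or a primary amide could stand in place of the carboxylic acid on this ring.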